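This account rests on a few compounds, and the source may have more. Where it says the series, first, only, none or still open, it means among the compounds named here.

Measured so far in a functional assay on MIA PaCa-2 cells (Homo sapiens) for cytotoxicity, read by MTT assay, with a stated time of 4 h; a higher number here means a weaker inhibitor, a lower number a stronger inhibitor:
- compound 1 `COC1=CC(=O)c2c(COc3ccc([N+](=O)[O-])cc3)c(C)n(C)c2C1=O`: 638 nM
- compound 2 `COC1=CC(=O)c2c(COc3ccccc3)c(C)n(C)c2C1=O`: 4560 nM
- compound 3 `COC1=CC(=O)c2c(COc3ccc(C#N)cc3)c(C)n(C)c2C1=O`: 463 nM

Compound 3 sits level with compound 1, as a 1.4-fold lower number from compound 1 to compound 3 (0.14 log units; within the scatter) shows. Both are well apart from compound 2, which carries hydrogen at the same spot.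

The next compound is compound 4 `COC1=CC(=O)c2c(COc3ccc(F)cc3)c(C)n(C)c2C1=O`, with fluoro in place of cyano on an aromatic carbon.

Going by the values given here, no measured compound carries fluoro, so the size of this step is a judgement. Among the compounds with values here, two steps bear on it: a 9.8-fold lower number from compound 2 to compound 3 (0.99 log units; beyond the scatter), which is cyano in place of hydrogen, and a 7.1-fold higher number from compound 1 to compound 2 (0.85 log units; beyond the scatter), which is hydrogen in place of nitro. Both show how far the number moves between hydrogen and the two groups tested against it. Fluoro may land anywhere between those extremes, and a position nearer compound 2 seems more likely.

The expected change is a 5.4-fold higher number from compound 3 to compound 4 (0.73 log units; beyond the scatter), a rise probably beyond the scatter. For compound 4 the estimated value in this assay is 2500 nM, with an expected range from 900 nM to 6000 nM.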

Compound 4, half-maximal inhibitory concentration: 905 nM
Compound 4: the middle estimate sits 2.8-fold (0.44 log units) above what was measured; the range from low to high includes it.
By their numbers in this assay, from the lowest: compounds 3, 1 and 4 (each within the scatter of the next); then compound 2.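

Fluoro, with its single heavy atom, gives a 5.0-fold lower number from compound 2 to compound 4 (0.70 log units; beyond the scatter) and so joins cyano and nitro as a third group that separates clearly from hydrogen at this place on the aromatic ring. The steps of a 2.0-fold higher number from compound 3 to compound 4 (0.29 log units; within the scatter) and a 1.4-fold higher number from compound 1 to compound 4 (0.15 log units; within the scatter) show that fluoro cannot be told apart from cyano or nitro here, even though the change from cyano to fluoro removes a triple bond and a hydrogen-bond acceptor. Among these four compounds, then, compound 2 alone stands apart, and no measurement at hand explains why the three substituted compounds read alike.

Still open, as far as these compounds go, is whether an amine, a methoxy group or a carboxylic acid at this place would stay level with these three or fall back towards compound 2. From the compounds shown here alone, the effect of moving fluoro elsewhere on the ring also remains unknown.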